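A few compounds are considered here, and "the series" means these few. Any claim that something is new, unique, unknown or untested is made for them only; others in the source may bear on it.

Measured in an ADME assay on a cell-free system (plasma, Rattus norvegicus) for metabolic stability, read by LC-MS, with a stated time of 60 min, tested at 100 uM; a higher number here means that more of the compound is left, a lower number that less of the compound is left:
- compound 1 `Cc1c(OCCCCOc2ccc(C(=O)O)cc2F)ccc(C(=O)CC2CCCC2)c1O`: 97%
- compound 2 `COc1ccc(C(=O)O)cc1OCCCCOc1ccc(C(=O)CC2CCCC2)c(O)c1C`: 103%
- compound 3 `Cc1c(OCCCCOc2ccc(C(=O)O)c(Cl)c2)ccc(C(=O)CC2CCCC2)c1O`: 97%

Compound 2, at 103%, lies within the scatter of both other compounds, so the three cannot be ranked in this assay. The next compound, compound 4 `COc1ccc(C(=O)O)cc1OCCCCOc1ccc(C(=O)CC(C)C)c(O)c1C`, keeps the carboxy-bearing end of compound 2 and changes the other end of the molecule: isopropyl in place of cyclopentyl on a saturated chain carbon bound to a carbonyl carbon. In words, isopropyl stands in place of cyclopentyl on a saturated chain carbon bound to a carbonyl carbon.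

Among the compounds with values here, no measured step tests this change, since all three measured compounds carry cyclopentyl. The available steps only vary the carboxy-bearing aryl group: a number 6 percentage points higher from compound 1 to compound 2 (within the scatter), no change at the digits printed from compound 1 to compound 3 (within the scatter) and a number 6 percentage points lower from compound 2 to compound 3 (within the scatter). All three stay within the scatter, so they offer only indirect guidance. No shift beyond the scatter is therefore expected, and no direction can be assigned.

The expected step is a number 4 percentage points lower from compound 2 to compound 4 (within the scatter). For compound 4 the estimated value is 99%, with an expected range from 89% to 108%.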

Compound 4, percent of the compound remaining: 99%
Beside the measured number, compound 4's estimate shows no gap at the digits printed; measured number inside the range.
By their numbers in this assay, from the lowest: compounds 1, 3, 4 and 2 (each within the scatter of the next).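

In this assay, within the data shown here, isopropyl in place of cyclopentyl on a saturated chain carbon bound to a carbonyl carbon gives a number 4 percentage points lower from compound 2 to compound 4 (within the scatter) and so offers the first reading at this end of the molecule, since the earlier steps varied only the carboxy-bearing aryl group. Within the compounds shown, the ring of cyclopentyl can therefore give way to the open-chain isopropyl with no shift beyond the scatter in this read-out. No supporting data bear on why this change behaves as it does.

The compounds shown test this position with only these two carbon groups, on a single carboxy-bearing end, so it stays open whether the same holds with the 4-carboxy-2-fluorophenyl end of compound 1. Also open, from the compounds shown here alone, is how a phenyl ring, an amine or a longer chain would read at this place.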